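The source may report more compounds than this note shows. Statements on the series, on what has been measured and on what is new or still open speak of the compounds shown alone.

Compound 1 `CCn1c(C(=O)NCCN)ccc1C(CC)(CC)c1ccc(OCCC(O)(CC)CC)c(C)c1` gives 2420 nM in a functional assay on PC-3 cells (Homo sapiens) for antiproliferative activity, read by MTT assay, with a stated time of 48 h (a higher number here means a weaker inhibitor, a lower number a stronger inhibitor), the lowest of the three numbers. Compound 3 `CCn1c(C(=O)N(C)CCO)ccc1C(CC)(CC)c1ccc(OCCC(O)(CC)CC)c(C)c1` gives 3090 nM, and the step of a 1.3-fold higher number from compound 1 to compound 3 (0.11 log units; within the scatter) lies within the scatter. Compound 2 `C#CC(C)OC(=O)c1ccc(C(CC)(CC)c2ccc(OCCC(O)(CC)CC)c(C)c2)n1CC` gives 14800 nM, with a 6.1-fold higher number from compound 1 to compound 2 (0.79 log units; beyond the scatter). Compound 4 `CCn1c(C(=O)NC(C)CO)ccc1C(CC)(CC)c1ccc(OCCC(O)(CC)CC)c(C)c1` differs from compound 1 by 1-(hydroxymethyl)ethyl in place of 2-aminoethyl on an amide-type nitrogen. The amide-type nitrogen and the carbonyl carbon are kept, so the step of a 1.3-fold higher number from compound 1 to compound 3 (0.11 log units; within the scatter) is the closer guide: a change on the amide side chain that moved the number only within the scatter. The step of a 6.1-fold higher number from compound 1 to compound 2 (0.79 log units; beyond the scatter) concerns a (1-methylprop-2-yn-1-yl)oxy group on the carbonyl carbon and bears less on this change. A step within the scatter, possibly a slight rise, is therefore expected. Compound 4 is estimated at 3000 nM, range 1500 nM to 6500 nM, an expected step of a 1.2-fold higher number from compound 1 to compound 4 (0.09 log units; within the scatter).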

Compound 4, half-maximal inhibitory concentration: 7870 nM
Compound 4: the middle estimate sits 2.6-fold (0.42 log units) below what was measured; measured number outside the range, above it.
By their numbers in this assay, from the lowest: compounds 1 and 3 (each within the scatter of the next); then compounds 4 and 2 (each within the scatter of the next).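

On the amide-type nitrogen, 1-(hydroxymethyl)ethyl in place of 2-aminoethyl gives a step beyond the scatter (a 3.3-fold higher number from compound 1 to compound 4 (0.51 log units; beyond the scatter)), so the side chain is less forgiving than a 1.3-fold higher number from compound 1 to compound 3 (0.11 log units; within the scatter) suggested. Two amides that both carry a hydroxyl group also separate (a 2.5-fold higher number from compound 3 to compound 4 (0.41 log units; beyond the scatter)). Keeping an amide therefore does not by itself hold the number down, since compound 4 lies within the scatter of the (1-methylprop-2-yn-1-yl)oxy compound (a 1.9-fold lower number from compound 2 to compound 4 (0.27 log units; within the scatter)).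

Going by these compounds, whether the step follows from losing the amine or from the branched chain stays open; a plain 2-hydroxyethyl group on the same nitrogen would separate the two. No measurement on hand explains these steps.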